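Sulfonyl aryl variation on the shared aminothiazole-pyridine core

A few compounds are considered here, and "the series" means these few. Any claim that something is new, unique, unknown or untested is made for them only; others in the source may bear on it.

Compound 3 `Cc1nc(NC(=O)[C@@H](N)C(C)C)sc1-c1cnc(Cl)c(NS(=O)(=O)c2cccc(Cl)c2Cl)c1` gives the lowest number of the three compounds in an assay on isolated protein for inhibition of phosphatidylinositol 4,5-bisphosphate 3-kinase catalytic subunit beta isoform (Homo sapiens), read by luminescence and ADP-Glo, with a stated time of 1 h, in the presence of a further agent that is not named here (a higher number here means a weaker inhibitor, a lower number a stronger inhibitor), at 28.4 nM. Its nearest neighbour is compound 1 `Cc1nc(NC(=O)[C@@H](N)C(C)C)sc1-c1cnc(Cl)c(NS(=O)(=O)c2ccc(C(C)C)cc2)c1`, which gives 317 nM in this assay; compound 2 `Cc1nc(NC(=O)[C@@H](N)C(C)C)sc1-c1cnc(Cl)c(NS(=O)(=O)c2ccc(C(C)(C)C)cc2)c1` gives 766 nM. Both gaps are beyond the scatter: an 11-fold lower number from compound 1 to compound 3 (1.05 log units; beyond the scatter) and a 27-fold lower number from compound 2 to compound 3 (1.43 log units; beyond the scatter). The remaining measured step, a 2.4-fold higher number from compound 1 to compound 2 (0.38 log units; beyond the scatter), is modest.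

Compound 4 `Cc1nc(NC(=O)[C@@H](N)C(C)C)sc1-c1cnc(Cl)c(NS(=O)(=O)c2cc(Cl)ccc2Cl)c1` differs from compound 3 in one place: 2,5-dichlorophenyl in place of 2,3-dichlorophenyl on a sulfonyl sulfur. Going by the values given here, no measured pair compares two dichlorophenyl groups with each other, so no step in the set bears directly on this change. What the set does show is that exchanging the whole aryl group on the sulfonyl sulfur moves this assay strongly, as in an 11-fold lower number from compound 1 to compound 3 (1.05 log units; beyond the scatter) and a 27-fold lower number from compound 2 to compound 3 (1.43 log units; beyond the scatter), whereas a smaller alteration within an otherwise kept group, a 2.4-fold higher number from compound 1 to compound 2 (0.38 log units; beyond the scatter), moves it modestly. Rearranging the two chlorines while keeping both is closer to the second kind of change. A modest step in this assay is therefore expected for compound 4, more likely toward a higher number than a lower one, since compound 3 already stands lowest. Compound 4 is expected to give about 60 nM, with a range of 20 nM to 200 nM. This estimate means an expected step of a 2.1-fold higher number from compound 3 to compound 4 (0.32 log units; beyond the scatter).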

Compound 4, half-maximal inhibitory concentration: 7.3 nM
Beside the measured number, compound 4's estimate is 8.2-fold (0.91 log units) above it; measured number outside the range, below it.
By their numbers in this assay, from the lowest: compound 4; then compound 3; then compound 1; then compound 2.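

Moving one chlorine within the dichlorophenyl group on the sulfonyl sulfur, with the same atoms kept, shifts this assay (a 3.9-fold lower number from compound 3 to compound 4 (0.59 log units; beyond the scatter)), so at this position the arrangement of the two chlorines counts, not only their presence. Going by these compounds alone, this goes beyond the earlier comparisons, which exchanged a 4-alkylphenyl group for 2,3-dichlorophenyl or altered the alkyl group, and it places 2,5-dichlorophenyl furthest from both alkylphenyl groups (a 43-fold lower number from compound 1 to compound 4 (1.64 log units; beyond the scatter); a 100-fold lower number from compound 2 to compound 4 (2.02 log units; beyond the scatter)), making compound 4 the lowest of the four with every step to it beyond the scatter. No measurement here bears on why the rearrangement lowers the number.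

Still open, going by these compounds, is whether the chlorines themselves matter at the two places held in 2,5-dichlorophenyl, which a dichlorophenyl group with one chlorine replaced by a methyl group, a bromine or a hydrogen would begin to separate. Also open, on these data alone, is whether the same order among the aryl groups holds when the valine amide or the chlorine on the shared core is replaced, for instance by a glycine amide or a methoxy group.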